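Ethynyl to chloromethyl on the carbonyl carbon

A few compounds are considered here, and "the series" means these few. Any claim that something is new, unique, unknown or untested is made for them only; others in the source may bear on it.

In a functional assay on MGC-803 cells (Homo sapiens) for inhibition, read by MTT assay, with a stated time of 48 h (on this read-out higher numbers stand for weaker inhibition and lower numbers for stronger inhibition), compound 1 (`COCC(=O)N(Cc1ccc(OC)c(O)c1)c1cc(OC)c(OC)c(OC)c1`) gives 79 nM while compound 2 (`COc1ccc(CN(C(=O)C(C)Br)c2cc(OC)c(OC)c(OC)c2)cc1O`) gives 120 nM and compound 3 (`C#CC(=O)N(Cc1ccc(OC)c(O)c1)c1cc(OC)c(OC)c(OC)c1`) gives 170 nM as its reading. The place of the ethynyl member is fixed by a 2.2-fold higher number from compound 1 to compound 3 (0.33 log units; beyond the scatter) and by a 1.4-fold higher number from compound 2 to compound 3 (0.15 log units; within the scatter) in turn. Compound 4 (`COc1ccc(CN(C(=O)CCl)c2cc(OC)c(OC)c(OC)c2)cc1O`) has chloromethyl in place of ethynyl on a carbonyl carbon. For the measured compounds named here, no chloromethyl member has been measured, so these two steps, read backwards, are the only guide. Only a small step, not beyond the scatter, is therefore expected: a 1.5-fold lower number from compound 3 to compound 4 (0.19 log units; within the scatter) is the estimate. In this assay compound 4 is estimated at 110 nM within an expected range of 45 nM to 270 nM overall.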

Compound 4, half-maximal inhibitory concentration: 84 nM
Beside the measured number, compound 4's estimate is 1.3-fold (0.12 log units) above it, within the range that was stated.
By their numbers in this assay, from the lowest: compounds 1, 4, 2 and 3 (each within the scatter of the next, the first and the last beyond it).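

In this assay, the carbonyl carbon position responds to this change, with a 2.0-fold lower number from compound 3 to compound 4 (0.31 log units; beyond the scatter), so chloromethyl and ethynyl read apart here. The other two steps do not separate chloromethyl from its neighbours in the set: a 1.4-fold lower number from compound 2 to compound 4 (0.15 log units; within the scatter) and a 1.1-fold higher number from compound 1 to compound 4 (0.03 log units; within the scatter) leave 1-bromoethyl, methoxymethyl and chloromethyl unresolved. No available evidence explains the step from ethynyl to chloromethyl. Open, as far as these compounds go, is whether a plain methyl group on the carbonyl carbon reads like these three, which would test whether the chlorine matters at all. Also open, from the compounds shown here alone, is how an aminomethyl group or a longer chain reads here.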